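A few compounds are considered here, and "the series" means these few. Any claim that something is new, unique, unknown or untested is made for them only; others in the source may bear on it.

Measured so far in a functional assay on HeLa cells (Homo sapiens) for antiproliferative activity, read by MTT assay, with a stated time of 48 h; a lower number here means a stronger inhibitor, a higher number a weaker inhibitor:
Compound 1 `CCN(CC)Cc1cn(-c2cc3c(cc2F)c(=O)c(C(=O)NO)cn3C2CC2)nn1`: > 10000 nM
Compound 2 `O=C(NO)c1cn(C2CC2)c2cc(-n3cc(CN4CCCCC4)nn3)c(F)cc2c1=O`: > 10000 nM

Compound 2 stands at > 10000 nM, which is a limit of the assay and not a number. Compound 1 also stands at a limit, > 10000 nM. Compound 3 `CC(C)NCc1cn(-c2cc3c(cc2F)c(=O)c(C(=O)NO)cn3C2CC2)nn1` keeps the shared core and changes one group: isopropylamino in place of piperidin-1-yl on a saturated chain carbon bound to an aromatic carbon. In words, isopropylamino takes the place of piperidin-1-yl on a saturated chain carbon bound to an aromatic carbon.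

For the measured compounds named here, one measured step bears on this change, as it alters the group at the same place: a step that the two limits leave unreadable from compound 1 to compound 2. Its size cannot be read, so the remaining evidence is the limit of > 10000 nM in this assay, at which 2 of the 2 values shown sit. Going by the values given here, no step of readable size is therefore expected in this assay in either direction, and another limit is the likeliest result. The estimated change is a step that the limit leaves unreadable from compound 2 to compound 3. The estimate for compound 3 is 15000 nM, with an expected range from 5000 nM to 40000 nM.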

Compound 3, half-maximal inhibitory concentration: > 10000 nM
Compound 3 gave a limit, no number (the forecaster's own chance of this, stated with the estimate: 85%); the middle value is on the limit's open side.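

Compound 3 ends at a limit of the assay and not a number, as do compound 1 and compound 2, and no step among the three can be read: the limit of > 10000 nM in this assay, at which 3 of the 3 values shown sit.

The compounds shown leave open whether diethylamino, piperidin-1-yl and isopropylamino differ at all in strength, and whether any group at this place gives a measurable value.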